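Replacing 3-chlorophenyl with pyridin-3-yl in compound 2

The compounds below may be only part of what the source reports. "The series", "measured", "known", "first", "only" and "open" are said of these compounds alone.

Among the compounds with values here, only two compounds have numbers so far. In a functional assay on HCT-15 cells (Homo sapiens) for cytotoxicity, read by ELISA, with a stated time of 4 days (on this read-out higher numbers stand for weaker inhibition and lower numbers for stronger inhibition), compound 1 (`Clc1cccc(-c2cc(-c3ccoc3)cc(-c3ccc(Cl)s3)n2)c1`) gives 950 nM as its half-maximal inhibitory concentration, and compound 2 (`Cc1ccsc1-c1cc(-c2ccc(Cl)o2)cc(-c2cccc(Cl)c2)n1`) gives 26400 nM on the same read-out. Compound 2 therefore holds the higher number of the pair, and the gap lies well beyond the scatter of repeated measurements, so it is the weaker inhibitor of these two. The next compound, compound 3 (`Cc1ccsc1-c1cc(-c2ccc(Cl)o2)cc(-c2cccnc2)n1`), keeps all of compound 2 except one group: pyridin-3-yl in place of 3-chlorophenyl on an aromatic carbon. Within the data shown here, compound 1 and compound 2 differ in more than one place, so no measured pair shows what this swap does on its own. The step expected in this assay is therefore small, with no firm direction and nothing beyond the scatter (a 1.3-fold lower number from compound 2 to compound 3 (0.12 log units; within the scatter)). Taking compound 2 at 26400 nM as the starting point, a number of similar size is expected next. For compound 3 the estimate is 20000 nM as the expected value, within an expected range from 6000 nM to 60000 nM on this read-out.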

Compound 3, half-maximal inhibitory concentration: > 50000 nM
Compound 3 gave a limit, no number (the forecaster's own chance of this, stated with the estimate: 15%); at least 2.5-fold (0.39 log units) between middle value and limit.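

In this assay, within the data shown here, pyridin-3-yl in place of 3-chlorophenyl, on the aromatic carbon next to the ring nitrogen, is the first single change that can be read on its own, and it gives an at least 1.8-fold higher number from compound 2 to compound 3 (0.27 log units; that floor lies within the scatter). That floor alone does not establish a loss, but it does show that this exchange, which brings a ring nitrogen and one hydrogen-bond acceptor and removes the chlorine, does not give compound 3 a measurable number in this series. How far the true value of compound 3 lies from that of compound 2 cannot be read, since only a limit stands on one side of the step: the limit of > 50000 nM in this assay, at which 1 of the 3 values shown sits.

Whether the same swap would act alike on the core of compound 1, which also carries 3-chlorophenyl, stays open, as the compounds shown hold no such pair. Also open, from the compounds shown here alone, is what other groups at this position would do, such as a plain phenyl without chlorine, a phenyl ring carrying an amine, or one carrying a carboxylic acid.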